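Butoxy for nitro: expectation for compound 4

The compounds below may be only part of what the source reports. "The series", "measured", "known", "first", "only" and "open" are said of these compounds alone.

Compound 2 `O=C(c1ccc([N+](=O)[O-])cc1)n1nnc2ccccc21` gives 2970 nM in an assay on isolated protein for inhibition of Alpha glucosidase (Homo sapiens); a lower number here means a stronger inhibitor, a higher number a weaker inhibitor; this is the lowest of the three numbers, but compound 1 `COc1ccc(C(=O)n2nnc3ccccc32)cc1` at 2990 nM and compound 3 `Cc1cc(C(=O)n2nnc3ccccc32)ccc1[N+](=O)[O-]` at 4100 nM both lie within the scatter of it, so no order among the three is claimed. Compound 4 `CCCCOc1ccc(C(=O)n2nnc3ccccc32)cc1` differs from compound 2 by butoxy in place of nitro on an aromatic carbon. The step that bears on this is a 1.0-fold lower number from compound 1 to compound 2 (0.00 log units; within the scatter), where an alkoxy group and a nitro group gave the same number; the methyl step a 1.4-fold higher number from compound 2 to compound 3 (0.14 log units; within the scatter) was also flat. Nothing in this assay has moved beyond the scatter, so no step beyond it is expected for the longer alkoxy chain. Compound 4 is expected to give 3000 nM, between 1500 nM and 6000 nM. The expected step is a 1.0-fold higher number from compound 2 to compound 4 (0.00 log units; within the scatter).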

Compound 4, half-maximal inhibitory concentration: 5600 nM
Compound 4: the middle estimate sits 1.9-fold (0.27 log units) below what was measured; low and high end bracket the measured number.
By their numbers in this assay, from the lowest: compounds 2, 1, 3 and 4 (each within the scatter of the next).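

In this assay, for the compounds shown here, the step for butoxy in place of nitro is a 1.9-fold higher number from compound 2 to compound 4 (0.28 log units; within the scatter) and the step from methoxy to butoxy is a 1.9-fold higher number from compound 1 to compound 4 (0.27 log units; within the scatter) and these are the largest steps so far. Even so, this place, para to a large group, accepts a chain of 5 heavy atoms without a step beyond the scatter. The data shown offer no measurement that explains these numbers.

Still open, on these data alone, is whether a longer chain than butoxy, an amine or a carboxylic acid at this place would give a step beyond the scatter.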